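A few compounds are considered here, and "the series" means these few. Any claim that something is new, unique, unknown or untested is made for them only; others in the source may bear on it.

Measured in a physicochemical assay for solubility, measured as kinetic solubility, with a stated time of 1 h, at pH 7.4; a lower number here means a less soluble compound, a higher number a more soluble compound:
Compound 1 `N#CCCC(=O)NC1=NN(c2ccc(Cl)c(Cl)c2)CC1` gives 39000 nM
Compound 2 `O=C1CCCC(C(=O)NC2=NN(c3ccc(Cl)c(Cl)c3)CC2)N1` gives 416000 nM
Compound 3 `O=C(NC1=NN(c2ccc(Cl)c(Cl)c2)CC1)c1ccncn1` gives 13000 nM

Compound 3 has the lowest number of the three in this assay and both steps leading to it are beyond the scatter. One is a 3.0-fold lower number from compound 1 to compound 3 (0.48 log units; beyond the scatter) and counts as modest, while the other is a 32-fold lower number from compound 2 to compound 3 (1.51 log units; beyond the scatter) and counts as large.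

Compound 4 `O=C(NC1=NN(c2ccc(Cl)c(Cl)c2)CC1)c1ccncc1F` shares the core of compound 3 and differs in one group, with 3-fluoropyridin-4-yl in place of pyrimidin-4-yl on a carbonyl carbon. Within the data shown here, all the measured steps change this same place, and the third of them, an 11-fold higher number from compound 1 to compound 2 (1.03 log units; beyond the scatter) and also large, shows how far the number can move there. Each of these steps, however, involves a 2-cyanoethyl or a 6-oxopiperidin-2-yl group. None exchanges one six-membered aromatic ring for another, so they offer only a loose guide to this change, and the wide range below reflects that.

No step beyond the scatter is therefore expected, and the expected change is a 1.3-fold lower number from compound 3 to compound 4 (0.11 log units; within the scatter) with only a slight lean in that direction. In this assay the estimated value for compound 4 is 10000 nM with 3000 nM and 32000 nM as the expected ends of its range.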

Compound 4, solubility: 36000 nM
Compound 4: the middle estimate sits 3.6-fold (0.56 log units) below what was measured; measured number outside the range, above it.
By their numbers in this assay, from the lowest: compound 3; then compounds 4 and 1 (each within the scatter of the next); then compound 2.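

In this assay, among these compounds, this is the first exchange of one six-membered aromatic ring for another on a carbonyl carbon whose other neighbour is an amide-type nitrogen, and a 2.8-fold higher number from compound 3 to compound 4 (0.44 log units; beyond the scatter) shows that the choice between two such rings can itself move the number beyond the scatter. The aromatic ring as such therefore does not fix the number here: a 1.1-fold lower number from compound 1 to compound 4 (0.03 log units; within the scatter) places 3-fluoropyridin-4-yl level with the open 2-cyanoethyl group, whereas pyrimidin-4-yl stays apart from that group. The result also leaves the 6-oxopiperidin-2-yl group clear of all three other groups, with a 12-fold lower number from compound 2 to compound 4 (1.06 log units; beyond the scatter) adding to the steps already seen for it, but nothing available bears on what lies behind any of these differences.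

As far as these compounds go, the step from compound 3 to compound 4 alters the ring hetero atoms and brings in fluorine in a single exchange, so the share of each remains open. A plain pyridin-4-yl or phenyl group in this place would separate the two, and an amine or carboxylic acid on the ring would test how far the number can rise among aromatic groups.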